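The compounds below may be only part of what the source reports. "The series", "measured", "known", "first", "only" and "open" are said of these compounds alone.

Compound 1 `Cc1cccc(C(=O)N(C(=S)OCCN2C(=O)c3ccccc3C2=O)c2ccc(Cl)cc2)c1` gives 58000 nM
Compound 2 `O=C1c2ccccc2C(=O)N1CCOC(=S)N(C(=O)c1c(F)cccc1F)c1ccc(Cl)cc1` gives 39000 nM
Compound 3 `O=C1c2ccccc2C(=O)N1CCOC(=S)N(C(=O)c1cc(F)cc(F)c1)c1ccc(Cl)cc1` gives 59000 nM

In an ADME assay on MT4 cells (Homo sapiens) for cytotoxicity, read by MTT assay (on this read-out higher numbers stand for lower toxicity in this test and lower numbers for higher toxicity in this test), compound 3 stands within the scatter of both compound 1 and compound 2. Compound 4 `COc1cccc(OC)c1C(=O)N(C(=S)OCCN1C(=O)c2ccccc2C1=O)c1ccc(Cl)cc1` has not yet been measured and differs from compound 3 as follows: 2,6-dimethoxyphenyl in place of 3,5-difluorophenyl on a carbonyl carbon. Three measured steps at this same place bear on the change: a 1.0-fold higher number from compound 1 to compound 3 (0.01 log units; within the scatter) and a 1.5-fold higher number from compound 2 to compound 3 (0.18 log units; within the scatter) and also a 1.5-fold lower number from compound 1 to compound 2 (0.17 log units; within the scatter). All three lie within the scatter. Within the data shown here, no measured compound carries 2,6-dimethoxyphenyl, which leaves the estimate uncertain. In this assay no step beyond the scatter is therefore expected, and the estimated change is a 1.2-fold lower number from compound 3 to compound 4 (0.07 log units; within the scatter) in size. For compound 4 the expected value is 50000 nM with an estimated range of 22000 nM to 100000 nM.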

Compound 4, half-maximal cytotoxic concentration: 69000 nM
Compound 4: middle estimate off by 1.4-fold (0.14 log units), on the low side; measured number inside the range.
By their numbers in this assay, from the lowest: compounds 2, 1, 3 and 4 (each within the scatter of the next).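

In this assay, among these compounds, the only group here with hydrogen-bond acceptors, 2,6-dimethoxyphenyl on a carbonyl carbon, stays within the scatter of all three other groups (a 1.2-fold higher number from compound 3 to compound 4 (0.07 log units; within the scatter)) and (a 1.8-fold higher number from compound 2 to compound 4 (0.25 log units; within the scatter)) and (a 1.2-fold higher number from compound 1 to compound 4 (0.08 log units; within the scatter)). Across the four groups shown, then, this position gives no step beyond the scatter, even with hydrogen-bond acceptors entering there. On these data alone, whether an amine, a carboxylic acid or a longer chain at this place would give such a step stays open. No measured evidence on the reason for this result is available.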